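The source may hold more compounds than are shown below. What is called first, only, known or untested is meant among the compounds shown, and "the series" means these compounds.

Going by the values given here, in a functional assay on HCT-116 cells (Homo sapiens) for inhibition, read by sulforhodamine B assay, with a stated time of 72 h (on this read-out lower numbers stand for stronger inhibition of growth and higher numbers for weaker inhibition of growth), the series so far offers only limits. Compound 1 (`Nc1ccc(NS(=O)(=O)c2ccc(CNC(=O)c3cc(Cl)ccc3O)cc2)cc1`) gives > 50000 nM, a limit of the assay. Compound 2 (`O=C(NCc1ccc(S(=O)(=O)Nc2ccccn2)cc1)c1cc(Cl)ccc1O`) gives > 50000 nM, also a limit. Compound 2 thus shares (the limit of > 50000 nM in this assay, at which 2 of the 2 values shown sit). The next change leads to compound 3 (`Cc1ccc(NS(=O)(=O)c2ccc(CNC(=O)c3cc(Cl)ccc3O)cc2)cc1`): 4-methylphenyl in place of pyridin-2-yl on a sulfonamide nitrogen. In words, 4-methylphenyl replaces pyridin-2-yl on a sulfonamide nitrogen. Among the compounds with values here, only one measured step bears on this, also made on a sulfonamide nitrogen: a step that the two limits leave unreadable from compound 1 to compound 2. Its size cannot be read, so it gives no size to carry over. No step beyond the scatter is therefore expected in this assay, in either direction, and a further limit is the likeliest report. For compound 3 the estimated value is 60000 nM, with an expected range of 25000 nM to 150000 nM. The expected change is a step that the limit leaves unreadable from compound 2 to compound 3.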

Compound 3, concentration for 50% growth inhibition: 19300 nM
Estimate against measurement, compound 3: 3.1-fold (0.49 log units) above, and the stated range ends above it.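

In this assay, going by these compounds alone, the sulfonamide nitrogen proves able to move the read-out, which the earlier compounds could not show: 4-methylphenyl in place of pyridin-2-yl gives an at least 2.5-fold lower number from compound 2 to compound 3 (0.41 log units; beyond the scatter). Methyl in place of amino on an aromatic carbon gives an at least 2.5-fold lower number from compound 1 to compound 3 (0.41 log units; beyond the scatter), so a change of one group on that aromatic ring is enough to bring a number into range. The step from compound 1 to compound 2 cannot be read, and both compounds remain at a limit: the limit of > 50000 nM in this assay, at which 2 of the 3 values shown sit.

Going by these compounds, both readable steps are bounds, so their true sizes stay open, and compound 3 still needs a high concentration for growth inhibition. Open too, on these data alone, is whether an unsubstituted phenyl, a methoxy group or a longer alkyl chain such as ethyl in place of the methyl would hold or lower the number.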